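This account rests on a few compounds, and the source may have more. Where it says the series, first, only, none or still open, it means among the compounds named here.

Compound 1 `CN(C)CCCCOc1ccc2oc(-c3ccccc3)cc(=O)c2c1` is the reference point of this small set. In an assay on isolated protein (Cavia porcellus) with Sigma non-opioid intracellular receptor 1 (Homo sapiens) as the target, read by radioligand binding (a lower number here means a stronger inhibitor, a higher number a weaker inhibitor), compound 1 gives 400 nM, the highest number of the three measured compounds. Compound 2 `CN(C)CCCCCCCCCOc1ccc2oc(-c3ccccc3)cc(=O)c2c1` gives 202 nM in this assay, and compound 3 `O=c1cc(-c2ccccc2)oc2ccc(OCCCCCCN3CCCCC3)cc12` gives 54 nM. Compound 4 `CCN(CC)CCCCCCOc1ccc2oc(-c3ccccc3)cc(=O)c2c1` has not yet been measured; it differs from compound 1 in one place: 2-(diethylamino)ethyl in place of dimethylamino on a saturated chain carbon, four bonds along the chain from an oxygen on an aromatic ring. Among the compounds with values here, two measured steps bear on this change. Lengthening the chain while keeping dimethylamino, in a 2.0-fold lower number from compound 1 to compound 2 (0.30 log units; within the scatter), stayed within the scatter. Lengthening the chain while putting piperidin-1-yl in place of dimethylamino, in a 7.4-fold lower number from compound 1 to compound 3 (0.87 log units; beyond the scatter), gave a modest lowering, and a 3.7-fold lower number from compound 2 to compound 3 (0.57 log units; beyond the scatter) pointed the same way. The change to compound 4 lengthens the chain and enlarges the amine, but with diethylamino rather than a ring, so a lowering between those two outcomes is expected in this assay, namely a 2.9-fold lower number from compound 1 to compound 4 (0.46 log units; beyond the scatter). Compound 4 is therefore estimated at 140 nM, with a range from 50 nM to 400 nM.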

Compound 4, half-maximal inhibitory concentration: 100 nM
Beside the measured number, compound 4's estimate is 1.4-fold (0.15 log units) above it; low and high end bracket the measured number.
By their numbers in this assay, from the lowest: compounds 3 and 4 (each within the scatter of the next); then compounds 2 and 1 (each within the scatter of the next).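

In this assay, exchanging piperidin-1-yl for diethylamino on the same chain stays within the scatter, with a 1.9-fold higher number from compound 3 to compound 4 (0.27 log units; within the scatter), so at this position an open-chain amine end serves about as well as the ring. Lengthening the chain and enlarging the amine together gives a 4.0-fold lower number from compound 1 to compound 4 (0.60 log units; beyond the scatter), a step beyond the scatter, and compound 4 also stands apart from the longer-chain dimethylamino compound, with a 2.0-fold lower number from compound 2 to compound 4 (0.31 log units; beyond the scatter), which suggests that chain length alone does not account for the change. Nothing given here explains these steps.

Going by these compounds, how much of the lowering belongs to the chain and how much to the amine stays open, since each step to compound 4 from compound 1 or compound 2 changes both. Also open, on these data alone, is how a pyrrolidine or morpholine ring at the end of this chain would compare with diethylamino.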